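The source may hold more compounds than are shown below. What is called first, only, known or untested is meant among the compounds shown, and "the series" means these compounds.

Measured in a functional assay on DU-145 cells (Homo sapiens) for antiproliferative activity, read by sulforhodamine B assay, with a stated time of 48 h; on this read-out lower numbers stand for stronger inhibition and higher numbers for weaker inhibition:
- compound 1 `CCCCN(C)C(=O)CCCOc1cc(OC)c(OC)c2oc(-c3ccc(OC)cc3)c(O)c(=O)c12`: > 40000 nM
- compound 2 `COc1ccc(-c2oc3c(OC)c(OC)cc(OCCCCC(=O)NCc4ccccn4)c3c(=O)c2O)cc1`: > 40000 nM
- compound 3 `COc1ccc(-c2oc3c(OC)c(OC)cc(OCCCCC(=O)N4CCN(C)CC4)c3c(=O)c2O)cc1`: > 40000 nM

Compound 2 stands at > 40000 nM, which is a limit of the assay and not a number. The same is true across the set: the limit of > 40000 nM in this assay, at which 3 of the 3 values shown sit.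

The unmeasured compound 4 `COc1ccc(-c2oc3c(OC)c(OC)cc(OCCCCCC(=O)N4CCN(C)CC4)c3c(=O)c2O)cc1` departs from compound 2 by one change: ((4-methylpiperazin-1-yl)carbonyl)methyl in place of ((pyridin-2-yl)methyl)carbamoyl on a saturated chain carbon, four bonds along the chain from an oxygen on an aromatic ring. In words, ((4-methylpiperazin-1-yl)carbonyl)methyl sits in place of ((pyridin-2-yl)methyl)carbamoyl on a saturated chain carbon, four bonds along the chain from an oxygen on an aromatic ring.

The closest measured change is a step that the two limits leave unreadable from compound 2 to compound 3, which also brings in 4-methylpiperazin-1-yl. The other two are a step that the two limits leave unreadable from compound 1 to compound 2 and a step that the two limits leave unreadable from compound 1 to compound 3. None of the three has a readable size, so no measured size carries over, and no direction can be drawn from them. Weak activity is still expected in this assay because of the limit of > 40000 nM in this assay, at which 3 of the 3 values shown sit.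

For compound 4 the estimated value is 40000 nM, with an expected range of 15000 nM to 60000 nM. This estimate amounts to an expected a number no higher from compound 2 to compound 4 (the limit leaves the size open), most likely reported only as a limit again.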

Compound 4, half-maximal inhibitory concentration: 13200 nM
Compound 4: the middle estimate sits 3.0-fold (0.48 log units) above what was measured; measured number outside the range, below it.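

In this assay compound 4 is the only compound shown that gives a real number and not a limit: the limit of > 40000 nM in this assay, at which 3 of the 4 values shown sit.

With the 4-methylpiperazin-1-yl amide kept, the longer chain gives an at least 3.0-fold lower number from compound 3 to compound 4 (0.48 log units; beyond the scatter), so at this position chain length alone moves the result. The other two comparisons, an at least 3.0-fold lower number from compound 2 to compound 4 (0.48 log units; beyond the scatter) and an at least 3.0-fold lower number from compound 1 to compound 4 (0.48 log units; beyond the scatter), change both the amide and the chain, and all three sizes are minimums, as each starts from a limit.

As far as these compounds go, the steps among compound 1, compound 2 and compound 3 cannot be read, so the separate part played by the amide group remains unknown. Also open, from the compounds shown here alone, is whether a still longer chain, or a morpholine amide or a carboxylic acid at the chain end, would lower the number further.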